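Aryl swap at the amide end: chloro for methyl

A few compounds are considered here, and "the series" means these few. Any claim that something is new, unique, unknown or untested is made for them only; others in the source may bear on it.

Two compounds of the series carry numbers in a functional assay on HeLa cells (Homo sapiens) for cytotoxicity, read by MTT assay, with a stated time of 72 h; on this read-out lower numbers stand for stronger inhibition and higher numbers for weaker inhibition. Compound 1 `O=C(Nc1ccc(Oc2ccnc3[nH]ccc23)cc1)c1cc(-c2ccccc2)ncn1` gives 400 nM. Compound 2 `Cc1ccc(-c2ccnc(C(=O)Nc3ccc(Oc4ccnc5[nH]ccc45)c(F)c3)n2)cc1` gives 5510 nM, the highest of the two numbers; compound 1 is the nearest to it, and the gap between them lies beyond the scatter. Among the measured compounds shown here, the two compounds differ in more than one place, so no single step is drawn between them, and the source of the gap stays open.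

Compound 3 `O=C(Nc1ccc(Oc2ccnc3[nH]ccc23)c(F)c1)c1nccc(-c2cccc(Cl)c2)n1` is not yet measured. It differs from compound 2 by 3-chlorophenyl in place of 4-methylphenyl on an aromatic carbon. For the measured compounds named here, no measured pair isolates this exchange, so its effect in this assay is unknown from the data at hand. For compound 3 the expected step of a 1.6-fold lower number from compound 2 to compound 3 (0.20 log units; within the scatter) is small, within or barely beyond the scatter, with no firm direction. Compound 3 is therefore estimated at 3500 nM, with a range from 900 nM to 14000 nM.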

Compound 3, half-maximal inhibitory concentration: 3350 nM
The estimate for compound 3 lay 1.0-fold (0.02 log units) above the measured number; measured number inside the range.
By their numbers in this assay, from the lowest: compound 1; then compounds 3 and 2 (each within the scatter of the next).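

In this assay, among the compounds shown here, the exchange of 4-methylphenyl for 3-chlorophenyl on an aromatic carbon of the six-membered aromatic ring with 2 nitrogen gives the first single-place step: a 1.6-fold lower number from compound 2 to compound 3 (0.22 log units; within the scatter). At this position the two aryl groups therefore do not separate in this read-out, although both the substituent and its place on the phenyl ring differ, so the two contributions cannot be told apart and either could offset the other. No measurement of any property of these compounds bears on this result.

From the compounds shown here alone, compound 2 and compound 3 each differ in more than one place from compound 1 at 400 nM, so the source of that gap stays open. Also open, going by these compounds, is how an amine or a carboxylic acid on this phenyl ring would read.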